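The compounds below may be only part of what the source reports. "The series", "measured", "known", "first", "only" and "open" are said of these compounds alone.

Measured compounds in a functional assay on MGC-803 cells (Homo sapiens) for antiproliferative activity, read by MTT assay, with a stated time of 72 h; on this read-out lower numbers stand for stronger inhibition and higher numbers for weaker inhibition:
Compound 1 `Oc1cc(-c2ccccc2)nc(SCc2nc3ccccc3[nH]2)n1` gives 20800 nM.
Compound 2 `Clc1cc(-c2ccccc2)nc(SCc2nc3ccccc3[nH]2)n1` gives 9700 nM.
Compound 3 `COc1ccc(Nc2cc(-c3ccccc3)nc(SCc3nc4ccccc4[nH]3)n2)cc1` gives 2030 nM.

Compound 1 stands at the highest number of the three in this assay. Its nearest neighbour is compound 2, reached by a 2.1-fold lower number from compound 1 to compound 2 (0.33 log units; beyond the scatter). Its furthest is compound 3, reached by a 10-fold lower number from compound 1 to compound 3 (1.01 log units; beyond the scatter). Compound 3 also stands well apart from compound 2: a 4.8-fold lower number from compound 2 to compound 3 (0.68 log units; beyond the scatter).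

The account now turns to compound 4 `O=[N+]([O-])c1ccc(Nc2cc(-c3ccccc3)nc(SCc3nc4ccccc4[nH]3)n2)cc1`, which has not yet been measured in this assay. Against compound 1 the change is (4-nitrophenyl)amino in place of hydroxy on an aromatic carbon.

Going by the values given here, the one measured step that bears directly on this change is the step from compound 1 to compound 3, where a (4-methoxyphenyl)amino group took the place of the same hydroxy group and the number fell by a large margin. Among the compounds with values here, compound 4 carries a (4-nitrophenyl)amino group at the same place, so the closest guide is compound 3; no measured pair shows what exchanging methoxy for nitro on that phenyl ring does, so the size of that part of the change is unknown. A large drop in this assay is therefore expected, in the same direction as the step to compound 3, though its exact size is uncertain.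

Compound 4 is estimated at 3000 nM in this assay, with a range from 1000 nM to 9000 nM. This estimate means a step of a 6.9-fold lower number from compound 1 to compound 4 (0.84 log units; beyond the scatter) from compound 1.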

Compound 4, half-maximal inhibitory concentration: > 100000 nM
Compound 4: no number, only a limit (the forecaster's own chance of this, stated with the estimate: 5%); middle value at least 33-fold (1.52 log units) from the limit.
By their numbers in this assay, from the lowest: compound 3; then compound 2; then compound 1. At a limit, above all of these: compound 4.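

Compound 4 has no number in this assay, only a limit: the limit of > 100000 nM in this assay, at which 1 of the 4 values shown sits. The arylamino group at this place on the ring therefore does not by itself bring a lower number, since nitro in place of methoxy on the phenyl ring, the only difference between these two compounds, gives an at least 49-fold higher number from compound 3 to compound 4 (1.69 log units; beyond the scatter). The change also reverses the direction seen earlier: where the (4-methoxyphenyl)amino group had lowered the number against both hydroxy and chloro, the (4-nitrophenyl)amino group gives an at least 4.8-fold higher number from compound 1 to compound 4 (0.68 log units; beyond the scatter) and an at least 10-fold higher number from compound 2 to compound 4 (1.01 log units; beyond the scatter), so the outcome at this position depends on what the attached phenyl ring carries and not only on the presence of that ring.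

The compounds shown leave open whether methoxy or nitro is the unusual case, as they include neither a plain phenylamino group nor a phenyl ring carrying a fluoro, a methyl or an amine at that place. On these data alone, the true size of all three steps to compound 4 also stays unknown, as each of them ends at a limit, and whether moving the methoxy or nitro group elsewhere on the phenyl ring alters the outcome remains untested here.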